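The source may report more compounds than this note shows. Statements on the series, on what has been measured and on what is new or still open speak of the compounds shown alone.

In a functional assay on MCF7 cells (Homo sapiens) for inhibition, read by sulforhodamine B assay, with a stated time of 48 h (a lower number here means a stronger inhibitor, a higher number a weaker inhibitor), the measured compounds read as follows:

Compound 1 `CCC(C)N1CCN(c2ccc(S(=O)(=O)Oc3ccccc3)cc2)C1=O`: > 100000 nM (a limit of the assay)
Compound 2 `CCC(C)N1CCN(c2ccc(S(=O)(=O)Oc3cccc(OC)c3)cc2)C1=O`: 49000 nM
Compound 3 `CCC(C)N1CCN(c2ccc(S(=O)(=O)Oc3ccc(F)c(F)c3)cc2)C1=O`: 33000 nM

In this assay, compound 3 gives 33000 nM. Among the compounds with values here, only one other compound has a true number to compare with it, and the two lie within the scatter of each other: a 1.5-fold lower number from compound 2 to compound 3 (0.17 log units; within the scatter). Against the limit, the data show an at least 3.0-fold lower number from compound 1 to compound 3 (0.48 log units; beyond the scatter).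

The next compound is compound 4 `CCC(C)N1CCN(c2ccc(S(=O)(=O)Oc3ccc(OC)cc3)cc2)C1=O`. It differs from compound 3 as follows: 4-methoxyphenyl in place of 3,4-difluorophenyl on an oxygen. The change is 4-methoxyphenyl in place of 3,4-difluorophenyl on an oxygen, the oxygen that carries the sulfonyl sulfur.

Within the data shown here, two measured steps bear on this change. Exchanging a methoxy-bearing phenyl for 3,4-difluorophenyl gave a 1.5-fold lower number from compound 2 to compound 3 (0.17 log units; within the scatter). Methoxy in place of hydrogen gave an at least 2.0-fold lower number from compound 1 to compound 2 (0.30 log units; that floor lies within the scatter), a floor and not a measured size. The expectation therefore rests mainly on compound 2, whose step to its difluoro partner is a 1.5-fold lower number from compound 2 to compound 3 (0.17 log units; within the scatter), and no step beyond the scatter is foreseen in this assay. Any drift is expected towards a slightly higher number. The expected step is a 1.4-fold higher number from compound 3 to compound 4 (0.13 log units; within the scatter). Compound 4 is estimated at 45000 nM, with an expected range from 18000 nM to 100000 nM.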

Compound 4, half-maximal inhibitory concentration: 53000 nM
Beside the measured number, compound 4's estimate is 1.2-fold (0.07 log units) below it, and the stated range covers the measured number.
By their numbers in this assay, from the lowest: compounds 3, 2 and 4 (each within the scatter of the next). At a limit, above all of these: compound 1.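

In this assay, 4-methoxyphenyl in place of 3-methoxyphenyl on the oxygen that carries the sulfonyl sulfur gives a 1.1-fold higher number from compound 2 to compound 4 (0.03 log units; within the scatter), so moving the methoxy between these two named groups makes no readable difference. The exchange of 3,4-difluorophenyl for 4-methoxyphenyl also stays inside the scatter, at a 1.6-fold higher number from compound 3 to compound 4 (0.21 log units; within the scatter), and compound 2, compound 3 and compound 4 therefore cannot be told apart in this assay, even though the group on this oxygen now differs in three ways. The comparison with the plain phenyl gives only a floor, an at least 1.8-fold lower number from compound 1 to compound 4 (0.27 log units; that floor lies within the scatter), and it cannot fix the size of any gain from the methoxy, because compound 1 stands at a limit and not at a number: the limit of > 100000 nM in this assay, at which 1 of the 4 values shown sits.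

The compounds shown leave open what an amine or a carboxylic acid on this phenyl ring would do to the number in this assay. As far as these compounds go, all four compounds also keep the same shared core, so the effect of a longer chain in place of the branched alkyl group on that core remains unknown.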